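Replacing an amino group with a carbamate-bearing propoxy chain

This account rests on a few compounds, and the source may have more. Where it says the series, first, only, none or still open, it means among the compounds named here.

Compound 2 `COc1cc2ncnc(-n3nc(-c4ccccn4)nc3N)c2cc1N` was tested in an assay on MCF7 cells for inhibition of Serine-protein kinase ATM (Homo sapiens), read by immunofluorescence, with a stated time of 1 h; a higher number here means a weaker inhibitor, a lower number a stronger inhibitor. In this assay compound 2 gives > 40000 nM, which is a limit of the assay rather than a number. Compound 1 `Nc1cc2c(-n3nc(-c4ccccn4)nc3N)ncnc2cc1Cl` differs from compound 2 by having chloro where compound 2 has methoxy. In this assay compound 1 gives > 40000 nM, again a limit. Among the measured compounds shown here, the only step among the measured compounds, a step that the two limits leave unreadable from compound 1 to compound 2, is therefore unreadable, since (the limit of > 40000 nM in this assay, at which 2 of the 2 values shown sit).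

Compound 3 `CCOC(=O)NCCCOc1cc2c(-n3nc(-c4ccccn4)nc3N)ncnc2cc1OC` is not yet measured. It differs from compound 2 as follows: 3-((ethoxycarbonyl)amino)propoxy in place of amino on an aromatic carbon. For the measured compounds named here, no measured step touches this kind of change, so there is nothing here to say how large its effect should be or in which direction. Compound 2 itself is known only as a limit, so any estimate for compound 3 starts from an uncertain footing. It is estimated that compound 3 will give 30000 nM, with a likely range from 5000 nM to 100000 nM. The step this estimate means, an at least 1.3-fold lower number from compound 2 to compound 3 (0.12 log units; that floor lies within the scatter), is expected with a real chance that the assay reports only a limit again.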

Compound 3, half-maximal inhibitory concentration in the Serine-protein kinase ATM assay: 800 nM
Beside the measured number, compound 3's estimate is 38-fold (1.57 log units) above it, outside the stated range (below it).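

Compound 3 is the only one of the three compounds with a real number in the Serine-protein kinase ATM assay, and the step from compound 1 to compound 2 cannot be read because both of its ends are limits: the limit of > 40000 nM in the Serine-protein kinase ATM assay, at which 2 of the 3 values shown sit.

Placing 3-((ethoxycarbonyl)amino)propoxy in place of amino, on the aromatic carbon ortho to a methoxy group, gives an at least 50-fold lower number from compound 2 to compound 3 (1.69 log units; beyond the scatter), so this position accepts a far larger chain than amino and the change brings a large gain in inhibition; the true size of the step stays open, since compound 2 is known only as a limit. In a physicochemical assay for solubility, in phosphate buffer, with a stated time of 18 h, at pH 7.4 (a lower number here means a less soluble compound, a higher number a more soluble compound), compound 2 gives 3000 nM, and compound 3 gives 16000 nM. The same change does not cost solubility, and the pair instead moves towards the more soluble side: the measured solubility of compound 2, 3000 nM, and of compound 3, 16000 nM, a 5.3-fold higher number (0.73 log units; beyond the scatter)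

The compounds shown cannot tell whether the gain comes from the carbamate, from the propoxy chain, or from both together. A propoxy chain ending in a free amine, or a shorter ethoxy chain carrying the same carbamate, would begin to separate these parts.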